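The source may report more compounds than this note shows. Statements on the series, on what has been measured and on what is new or still open speak of the compounds shown alone.

In a functional assay on A2058 cells (Homo sapiens) for antiproliferative activity, read by luminescence and CellTiter-Glo, with a stated time of 96 h (a lower number here means a stronger inhibitor, a higher number a weaker inhibitor), compound 3 `O=C(Nc1ccc(F)cc1)c1n[nH]cc1NC(=O)c1c(F)ccc(-c2ccc(F)nc2)c1F` gives 6310 nM, the highest of the three numbers, against compound 2 `O=C(Nc1ccc(F)cc1)c1n[nH]cc1NC(=O)c1c(F)ccc(-c2ccncc2)c1F` at 2940 nM and compound 1 `NC(=O)c1ccc(-c2ccc(F)c(C(=O)Nc3c[nH]nc3C(=O)Nc3ccc(F)cc3)c2F)cn1` at 295 nM. Compound 4 `NC(=O)c1cccc(-c2ccc(F)c(C(=O)Nc3c[nH]nc3C(=O)Nc3ccc(F)cc3)c2F)c1` differs from compound 3 by one swap, 3-carbamoylphenyl in place of 6-fluoropyridin-3-yl on an aromatic carbon. The most relevant measured change is a 21-fold higher number from compound 1 to compound 3 (1.33 log units; beyond the scatter), a large step in which fluoro replaces carbamoyl. Two modest steps, a 10-fold higher number from compound 1 to compound 2 (1.00 log units; beyond the scatter) and a 2.1-fold higher number from compound 2 to compound 3 (0.33 log units; beyond the scatter), show smaller shifts without a carbamoyl group. Compound 4 regains a carbamoyl group, so a lower number is expected in this assay, though probably not the full step, as its ring is of carbon only. The estimated step is an 11-fold lower number from compound 3 to compound 4 (1.02 log units; beyond the scatter). For compound 4 the expected value is 600 nM, within an estimated range of 180 nM to 2000 nM.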

Compound 4, half-maximal inhibitory concentration: 1990 nM
Compound 4: middle estimate off by 3.3-fold (0.52 log units), on the low side, and the stated range covers the measured number.
By their numbers in this assay, from the lowest: compound 1; then compounds 4 and 2 (each within the scatter of the next); then compound 3.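

In this assay, a carbamoyl group on a ring of carbon only recovers part of the loss seen with 6-fluoropyridin-3-yl (a 3.2-fold lower number from compound 3 to compound 4 (0.50 log units; beyond the scatter)) but does not match 6-carbamoylpyridin-3-yl (a 6.7-fold higher number from compound 1 to compound 4 (0.83 log units; beyond the scatter)). So at this position, the presence of a carbamoyl group does not alone set the number, and 3-carbamoylphenyl is within the scatter of pyridin-4-yl (a 1.5-fold lower number from compound 2 to compound 4 (0.17 log units; within the scatter)). No measurement here explains these differences.

Compounds 1 and 4 differ in both ring type and where the carbamoyl group sits, and these two changes remain unseparated. A 4-carbamoylphenyl group would test the second, and a carboxylic acid would test whether the carbamoyl group itself matters.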